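The source may report more compounds than this note shows. Statements on the series, on what has been measured and on what is new or still open speak of the compounds shown alone.

Compound 2 `Cc1ccccc1C(c1ccccc1)N1CCN(c2ncnc3c2cnn3-c2ccccc2)CC1` shares its core with compound 1 `c1ccc(-c2ccc(C(c3ccccc3)N3CCN(c4ncnc5c4cnn5-c4ccccc4)CC3)cc2)cc1`; the two differ only in the group on the saturated chain carbon bound to an amine nitrogen in a ring and an aromatic carbon, 2-methylphenyl in place of 4-phenylphenyl. In a functional assay on cells (Rhabdomyosarcoma cell, Homo sapiens) for cytotoxicity (a lower number here means a stronger inhibitor, a higher number a weaker inhibitor), compound 1 reaches only the limit of the assay, > 25000 nM. In this assay compound 2 likewise stops at the limit, > 25000 nM. The step that the two limits leave unreadable from compound 1 to compound 2 cannot be read; both values are limits, and the whole record comes to the limit of > 25000 nM in this assay, at which 2 of the 2 values shown sit. Compound 3 `c1ccc(C(c2ccccc2)N2CCN(c3ncnc4c3cnn4-c3ccccc3)CC2)cc1` is the compound to be measured next, and it differs from compound 2 by a single change: hydrogen in place of methyl on an aromatic carbon. Among the compounds with values here, no measured step gives a number for a change of this kind, so there is nothing to set a direction or a size for it. With both measured neighbours at the limit, compound 3 is expected to stay there as well, and the estimated step that the limit leaves unreadable from compound 2 to compound 3 means no readable movement. The estimate for compound 3 is 40000 nM, with a range from 20000 nM to 200000 nM, and a high chance that only a limit is reported once more.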

Compound 3, half-maximal inhibitory concentration: > 25000 nM
Compound 3: a limit, no number; the forecaster's own chance of this, stated with the estimate: 85%; the middle value does not contradict the limit.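

In this assay, within the data shown here, compound 3 also ends at a limit and gives no number, so no step among compound 1, compound 2 and compound 3 can be read, and the record stands as follows: the limit of > 25000 nM in this assay, at which 3 of the 3 values shown sit. The compounds shown leave open whether any change on the shared core gives a measurable value in this assay at all.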